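Diethylamino to dipropylamino: a small step expected

The source may hold more compounds than are shown below. What is called first, only, known or untested is meant among the compounds shown, and "the series" means these compounds.

compound 1 `CCN(CC)CC#CCCC1(C(O)(c2ccccc2)c2ccccc2)SCCCS1`: 500 nM; 500 nM (2 entries) (two entries, same value)
compound 2 `OC(c1ccccc1)(c1ccccc1)C1(CCC#CCN2CCCCC2)SCCCS1`: 1000 nM
compound 3 `CCN(CC)CC#CCCCC1(C(O)(c2ccccc2)c2ccccc2)SCCCS1`: 810 nM

All of these numbers come from a functional assay for antagonist activity, with Cavia porcellus as the target; on this read-out lower numbers stand for stronger inhibition and higher numbers for weaker inhibition. In this assay compound 3 gives 810 nM, and its nearest neighbour on the numbers is compound 2.

The next compound, compound 4 `CCCN(CC#CCCCC1(C(O)(c2ccccc2)c2ccccc2)SCCCS1)CCC`, has not yet been measured. It carries dipropylamino in place of diethylamino on a saturated chain carbon bound to a triple-bonded carbon.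

For the measured compounds named here, only one measured step bears on this change, and only loosely. It puts 4-(diethylamino)but-2-yn-1-yl in place of 3-(piperidin-1-yl)prop-1-yn-1-yl, so it also alters the amine end of the chain, and it came out as a 1.2-fold lower number from compound 2 to compound 3 (0.09 log units; within the scatter). Going by the values given here, no measured compound carries dipropylamino, so the data give no direction for this swap. A shift beyond the scatter is therefore not expected in this assay, and the estimated change is a 1.0-fold lower number from compound 3 to compound 4 (0.01 log units; within the scatter). The estimate for compound 4 is 800 nM, with an expected range from 320 nM to 2000 nM.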

Compound 4, antagonist equilibrium constant: 560 nM
Estimate against measurement, compound 4: 1.4-fold (0.15 log units) above, within the range that was stated.
By their numbers in this assay, from the lowest: compounds 4, 3 and 2 (each within the scatter of the next).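

Dipropylamino appears here for the first time, and in this assay putting it in place of diethylamino, on a saturated chain carbon bound to a triple-bonded carbon, gives a 1.4-fold lower number from compound 3 to compound 4 (0.16 log units; within the scatter) and so stays inside the usual scatter even though the group grows from 5 to 7 heavy atoms. A larger swap, in which a group of 11 heavy atoms with no ring replaces a group of 9 heavy atoms with a six-membered ring, gives a 1.8-fold lower number from compound 2 to compound 4 (0.25 log units; within the scatter) and so shows that these three amine ends are not told apart by this read-out. No supporting evidence bears on why the number responds so little to these changes.

Going by these compounds, it remains open whether a longer group on the nitrogen, such as dibutylamino, or a ring amine with a second hetero atom, such as morpholine, would move the number beyond the scatter. For the compounds shown here, it also remains open whether dipropylamino would behave in the same way on the shorter chain of compound 1, since here it is seen on only one chain length.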